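The compounds below may be only part of what the source reports. "The series", "measured", "known", "first", "only" and "open" are said of these compounds alone.

Compound 1 `C#CCn1cc(C(=O)NC(CC(=O)Nc2ccccc2)c2ccccc2)c(=O)c2cc(F)c(Cl)nc21` and compound 2 `C#CCn1cc(C(=O)NC(CC(=O)Nc2ccccc2)c2ccccc2)c(=O)c2ccc(Cl)nc21` share one core and were both tested in an ADME assay on NIH3T3 cells (Mus musculus) for cytotoxicity, read by MTT assay, with a stated time of 72 h; on this read-out lower numbers stand for stronger inhibition and higher numbers for weaker inhibition. In this assay compound 1 gives 9700 nM, and compound 2 gives 4400 nM. Among the measured compounds shown here, the one measured step, a 2.2-fold lower number from compound 1 to compound 2 (0.34 log units; beyond the scatter), is hydrogen in place of fluoro on an aromatic carbon. Compound 2 therefore stands at the lowest of the two numbers, with compound 1 as its nearest neighbour one such step higher. Compound 3 `C#CCn1cc(C(=O)NC(CC(=O)Nc2ccccc2)c2ccccc2)c(=O)c2cccnc21` differs from compound 2 by hydrogen in place of chloro on an aromatic carbon, again a halogen giving way to hydrogen on an aromatic carbon. For the measured compounds named here, only the step from compound 1 to compound 2 bears on this change, and it was modest. In this assay the expected step is a 1.3-fold lower number from compound 2 to compound 3 (0.10 log units; within the scatter), small and tending toward a lower number, though it may well fall within the scatter. The estimate for compound 3 in this assay is 3500 nM, with a range from 1200 nM to 10000 nM.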

Compound 3, half-maximal inhibitory concentration: "not active" (no number reported)
For compound 3 the study gives words and no number; there is nothing to compare the estimate with.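

Among the compounds shown here, compound 3 is reported only in words, as "not active", so no step from compound 2 to compound 3 can be read. From the compounds shown here alone, how far replacing the chloro with hydrogen shifts the number therefore stays open. No other data shown bear on this result.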